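A few compounds are considered here, and "the series" means these few. Any claim that something is new, unique, unknown or untested is made for them only; others in the source may bear on it.

Measured in a functional assay on A549 cells (Homo sapiens) for cytotoxicity, read by MTT assay, with a stated time of 68 h; a lower number here means a stronger inhibitor, a higher number a weaker inhibitor:
- compound 1 `O=C(Nc1cccc(-c2ccccc2C(F)(F)F)c1)C(Cl)Cl`: 7500 nM
- compound 2 `O=C(Nc1cccc(-c2cccc(F)c2)c1)C(Cl)Cl`: 9530 nM
- compound 3 `O=C(Nc1cccc(-c2ccsc2)c1)C(Cl)Cl`: > 50000 nM (a limit, not a number)

Only compound 1 and compound 2 have actual numbers here, and those two lie within the usual scatter of each other, so they cannot be ranked. Compound 3 reached only a limit of the assay.

Compound 4 `O=C(Nc1cccc(-c2ccccc2F)c1)C(Cl)Cl` is the next compound to consider. It keeps the core of compound 1 and makes one change: fluoro in place of trifluoromethyl on an aromatic carbon, at a place ortho to a large group. The counted difference is fluoro in place of trifluoromethyl on an aromatic carbon.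

Among the compounds with values here, no pair of measured compounds differs in just one place, so there is no direct guide to the size of this step. The best indication comes from compound 2, which also carries a fluoro group and gives 9530 nM. A fluoro compound with a number of that order makes a small step the likeliest outcome, perhaps toward a somewhat weaker number, and little beyond the scatter.

The expected change is a 1.5-fold higher number from compound 1 to compound 4 (0.17 log units; within the scatter).

For compound 4 the estimated value is 11000 nM, with an expected range from 4500 nM to 30000 nM.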

Compound 4, half-maximal inhibitory concentration: 13200 nM
Compound 4: the middle estimate sits 1.2-fold (0.08 log units) below what was measured, and the stated range covers the measured number.
By their numbers in this assay, from the lowest: compounds 1, 2 and 4 (each within the scatter of the next). At a limit, above all of these: compound 3.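

In this assay, within the data shown here, this is the first pair of compounds that differ in one place only, so it gives the first real measure of a change at this position: a 1.8-fold higher number from compound 1 to compound 4 (0.25 log units; within the scatter). The swap puts fluoro, with 1 heavy atom, in place of trifluoromethyl, with 4 heavy atoms, on an aromatic carbon ortho to a large group, and the two compounds still cannot be told apart in this assay. For this one pair, then, the position takes either group with no difference that the measurement can resolve, and both compounds give actual numbers rather than a limit.

As far as these compounds go, what a group of a different kind would do at this same place remains open, for example an amine, a carboxylic acid, a methoxy group or a longer chain such as propyl, and one pair cannot show whether the same swap would behave alike elsewhere on the ring. Compound 3 remains a limit and not a number, so its distance from the other compounds cannot be read: the limit of > 50000 nM in this assay, at which 1 of the 4 values shown sits.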